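Removing the six-atom chain at the ring carbon of compound 3

The compounds below may be only part of what the source reports. "The series", "measured", "known", "first", "only" and "open" are said of these compounds alone.

Compound 3 `CCCC[S+]([O-])c1nc(N)c2nc(O)n(Cc3ccccc3)c2n1` is one of three measured members of this series. In a functional assay on the whole organism for activation, with Mus musculus as the target (on this read-out higher numbers stand for an effect only at larger amounts of compound and lower numbers for an effect already at smaller amounts), compound 3 gives 1 mg/kg, level with compound 2 `CCCNc1nc(N)c2nc(O)n(Cc3ccccc3)c2n1`, which gives 1 mg/kg; together these two carry the highest numbers of the three. Compound 1 `CCCCCOc1nc(N)c2nc(O)n(Cc3ccccc3)c2n1` gives 0.3 mg/kg in this assay, and the step of a 3.3-fold higher number from compound 1 to compound 3 (0.52 log units; beyond the scatter) stands beyond the scatter, as does a 3.3-fold higher number from compound 1 to compound 2 (0.52 log units; beyond the scatter). The pair of compounds 2 and 3 shows no change at the digits printed from compound 2 to compound 3 (within the scatter).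

Compound 4 `Nc1nc(O)nc2c1nc(O)n2Cc1ccccc1` is not yet measured. It differs from compound 3 in one place: one oxygen atom in place of a group of 6 heavy atoms (4 carbon, 1 oxygen, 1 sulfur; no ring), on an aromatic carbon. The place is on an aromatic carbon of a six-membered aromatic ring, part of a fused system of two rings, meta to an amino group.

The three measured steps all concern the group at this same carbon. Swapping pentyloxy for propylamino or for the six-atom sulfur-containing chain shifted the number by a modest amount; swapping the latter two against each other shifted nothing beyond the scatter. Going by the values given here, no measured compound carries a group as small as hydroxy at this position, so the direction rests on weaker ground. A modest shift toward a higher number is expected, a 3.0-fold higher number from compound 3 to compound 4 (0.48 log units; beyond the scatter), in this assay. Compound 4 is estimated at 3 mg/kg, with a range from 1 mg/kg to 10 mg/kg.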

Compound 4, minimum effective dose: 1 mg/kg
For compound 4 the middle estimate is 3.0-fold (0.48 log units) above the measured one; low and high end bracket the measured number.
By their numbers in this assay, from the lowest: compound 1; then compounds 2, 3 and 4 (each within the scatter of the next).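

With hydroxy on this aromatic carbon, between two ring nitrogen atoms, compound 4 cannot be separated in this assay from the group of 6 heavy atoms (no change at the digits printed from compound 3 to compound 4 (within the scatter)) or from propylamino (no change at the digits printed from compound 2 to compound 4 (within the scatter)), so a single oxygen here reads the same as these two much larger groups. Pentyloxy alone stands apart, now against hydroxy as well (a 3.3-fold higher number from compound 1 to compound 4 (0.52 log units; beyond the scatter)), which leaves compound 1 as the only one of the four with a step beyond the scatter to each of the others, and the earlier picture of a modest shift away from pentyloxy now holds across three different replacements rather than two. Nothing available on these compounds accounts for compound 1 standing apart, or for the other three reading alike.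

The compounds shown do not settle whether the pentyloxy result depends on the length of the chain or on the oxygen linking it to the ring. Butoxy, hexyloxy or pentylamino at this carbon would separate those two readings, and a ring-bearing group such as benzyloxy would test whether the result extends beyond open chains.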